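From Methoxy to Methoxymethoxy on a Weak Inhibitor

The source may report more compounds than this note shows. Statements on the series, on what has been measured and on what is new or still open speak of the compounds shown alone.

In an ADME assay on HEK293 cells (Homo sapiens) for inhibition, read by MTT assay, with a stated time of 3 days (a higher number here means a weaker inhibitor, a lower number a stronger inhibitor), compound 1 `COc1ccc(/C=C\c2cc(OC)c(OC)c(OC)c2)cc1OCc1ccc(Br)cc1` gives 45000 nM and compound 2 `COc1cccc(/C=C/CCCOc2cc(/C=C\c3cc(OC)c(OC)c(OC)c3)ccc2OC)c1` gives 39000 nM on the same read-out. Among the compounds with values here, compound 2 thus stands level with compound 1, the only other measured compound, as the two numbers lie within the scatter of each other.

Compound 3 `COCOc1cccc(/C=C/CCCOc2cc(/C=C\c3cc(OC)c(OC)c(OC)c3)ccc2OC)c1` differs from compound 2 in one place, where 3-methoxyphenyl becomes 3-(methoxymethoxy)phenyl. The change is methoxy in place of hydrogen on a saturated chain carbon bound to an oxygen on an aromatic ring and leaves the rest of the structure untouched.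

Within the data shown here, only one measured step bears on this, and it is an indirect guide. Replacing 4-bromophenyl with 4-(3-methoxyphenyl)but-3-en-1-yl gave a 1.2-fold lower number from compound 1 to compound 2 (0.06 log units; within the scatter) as its result. Among the measured compounds shown here, that larger exchange in the same part of the structure stayed within the scatter, so a smaller one is not expected to exceed it, although no measured compound carries a methoxymethoxy group.

The expected change is a 1.0-fold higher number from compound 2 to compound 3 (0.01 log units; within the scatter) and thus none beyond the scatter. In this assay the estimate for compound 3 is 40000 nM with an expected range of 18000 nM to 90000 nM in repeated measurements.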

Compound 3, half-maximal inhibitory concentration: 30000 nM
Estimate against measurement, compound 3: 1.3-fold (0.12 log units) above; the measured number falls inside the stated range.
By their numbers in this assay, from the lowest: compounds 3, 2 and 1 (each within the scatter of the next).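

In this assay, methoxy in place of hydrogen on a saturated chain carbon bound to an oxygen on an aromatic ring gives a 1.3-fold lower number from compound 2 to compound 3 (0.11 log units; within the scatter). The earlier step, a 1.2-fold lower number from compound 1 to compound 2 (0.06 log units; within the scatter), exchanged a whole aryl-bearing group and so could say nothing about a small edit to the 3-methoxyphenyl group itself; this step reads that edit directly and shows that going to 3-(methoxymethoxy)phenyl, which adds 2 heavy atoms and 1 hydrogen-bond acceptor, leaves compound 3 level with compound 2 on this read-out. No measurement is available that would explain why this change leaves the number within the scatter.

The compounds shown leave open whether a hydroxyl group, an amine or a carboxylic acid in place of the methoxymethoxy group, or a longer chain in place of the but-3-en-1-yl linker, would carry the number beyond the scatter. They also leave open whether any change to the shared core, which stays the same in all three compounds, would do so where these changes at the far end of the chain have not.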